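Adding a Nitro Group to Compound 2

The source may hold more compounds than are shown below. What is called first, only, known or untested is meant among the compounds shown, and "the series" means these compounds.

Measured in a functional assay on DU-145 cells (Homo sapiens) for cytotoxicity, read by trypan blue exclusion, with a stated time of 96 h; on this read-out higher numbers stand for weaker inhibition and lower numbers for stronger inhibition:
compound 1 (`COc1ccc(NS(=O)(=O)/C=C/c2c(OC)cc(OC)cc2OC)cc1`) gives 200 nM
compound 2 (`COc1ccc(NS(=O)(=O)/C=C/c2cc(OC)c(OC)c(OC)c2)cc1`) gives 35000 nM
compound 3 (`COc1ccc(NS(=O)(=O)/C=C/c2c(F)cc(F)cc2F)cc1`) gives 75000 nM

Of these three numbers, compound 2 holds the second highest. Its number lies below that of compound 3 and far above that of compound 1, and both gaps are beyond the scatter. The gap to compound 3 is much the smaller of the two.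

The next compound is compound 4 (`COc1ccc(NS(=O)(=O)/C=C/c2cc(OC)c(OC)c(OC)c2)cc1[N+](=O)[O-]`), which differs from compound 2 at one place, with nitro in place of hydrogen on an aromatic carbon

Among the measured compounds shown here, no measured compound carries a nitro group, and no measured pair differs in one place, so the data show no direct precedent for this change. Compound 2, at 35000 nM, already sits near the top of the measured span, while compound 1 reaches 200 nM, which leaves more room downward than upward. A moderate move toward stronger inhibition in this assay is therefore expected, beyond the scatter but with wide uncertainty, an estimated step of a 5.8-fold lower number from compound 2 to compound 4 (0.77 log units; beyond the scatter) in that direction. The expected value for compound 4 is 6000 nM, with an estimated range from 600 nM to 60000 nM in this measurement.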

Compound 4, half-maximal inhibitory concentration: 75000 nM
Compound 4: the middle estimate sits 13-fold (1.10 log units) below what was measured; the measured number lies above the stated range.
By their numbers in this assay, from the lowest: compound 1; then compound 2; then compounds 3 and 4 (each within the scatter of the next).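

In this assay, nitro in place of hydrogen on an aromatic carbon, ortho to a methoxy group and meta to a large group, gives a 2.1-fold higher number from compound 2 to compound 4 (0.33 log units; beyond the scatter), a modest move toward weaker inhibition. Among the compounds shown here, this is the first step in the set between compounds that differ in one place, so it gives the first direct reading of this position, and that reading is that this change raises the number rather than lowering it, though not by much. Nothing measured here accounts for the direction or size of this step.

The compounds shown leave open whether an amine or a carboxylic acid on the same aromatic carbon would move the number in the same direction as nitro or in the opposite one. Also open, going by these compounds, is whether nitro at this position would give a step of similar size on the core of compound 1, which stands at 200 nM in this assay, so this single step cannot be taken as a rule for the series.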